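This account rests on a few compounds, and the source may have more. Where it says the series, first, only, none or still open, it means among the compounds named here.

Compound 1 `CC[C@H]1N=C(N)[Se][C@H]1C` gives 21 nM in an assay on isolated protein for inhibition of Nitric oxide synthase, inducible (Homo sapiens) (a higher number here means a weaker inhibitor, a lower number a stronger inhibitor), while compound 2 `CC[C@H]1N=C(N)[Se][C@@H]1C` gives 9.4 nM, the lowest of the two numbers; the step of a 2.2-fold lower number from compound 1 to compound 2 (0.35 log units; beyond the scatter) rests on (the fact that compounds 1 and 2 differ only in the configuration as drawn). Compound 3 `CC[C@@H]1N=C(N)[Se][C@@H]1C` differs from compound 2 by the two compounds have the same atoms and bonds and differ only in configuration as drawn: 1 of 2 stereo elements differ; a stereocentre at a saturated ring carbon is drawn R in compound 2 and S in compound 3. Within the data shown here, the only measured step is also a change at a saturated ring carbon, and it was modest, so a similarly modest shift in this assay is expected, in either direction. For compound 3 the estimate is 15 nM (range 5 nM to 45 nM), an expected step of a 1.6-fold higher number from compound 2 to compound 3 (0.20 log units; within the scatter).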

Compound 3, half-maximal inhibitory concentration: 80 nM
Beside the measured number, compound 3's estimate is 5.3-fold (0.73 log units) below it; the whole stated range lies below it.
By their numbers in this assay, from the lowest: compound 2; then compound 1; then compound 3.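

Configuration at this second ring carbon counts for more than the first change suggested: an 8.5-fold higher number from compound 2 to compound 3 (0.93 log units; beyond the scatter) is a larger step than a 2.2-fold lower number from compound 1 to compound 2 (0.35 log units; beyond the scatter), and no atom enters or leaves. Inverting both stereocentres gives mirror images that also separate, with a 3.8-fold higher number from compound 1 to compound 3 (0.58 log units; beyond the scatter). The number in compound 3 therefore moves on the arrangement in space alone: the fact that compounds 2 and 3 differ only in the configuration as drawn

Still open, from the compounds shown here alone, is where the remaining mirror image of compound 2 would fall. Also open, going by these compounds, is whether a longer chain such as propyl on the shared core would keep this preference for one configuration.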